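The source may hold more compounds than are shown below. What is called first, only, known or untested is meant among the compounds shown, and "the series" means these compounds.

Compound 1 `CC(=O)Oc1ccccc1C(=O)O[C@H]1CO[C@H]2[C@@H]1OC[C@H]2OC(C)=O` is the reference ester of the shared core. Among the compounds with values here, in an ADME assay on a cell-free system (plasma, Homo sapiens) for metabolic stability, with Plasma (Rattus norvegicus) as the target, read by HPLC, at pH 7.4 (a lower number here means that the compound disappears faster, a higher number that the compound lasts longer), compound 1 gives 0.0095 h, the only plain number among the values shown. Compound 2 `CC(=O)Oc1ccccc1C(=O)O[C@H]1CO[C@H]2[C@@H]1OC[C@H]2OC(=O)c1ccc(-c2ccccc2)cc1` carries 4-phenylphenyl in place of methyl on a carbonyl carbon. In this assay compound 2 returns only a limit, > 0.333 h. Within the data shown here, the step of an at least 35-fold higher number from compound 1 to compound 2 (1.54 log units; beyond the scatter) is the single measured change, and it is large. Compound 3 `CCOc1cc(OCC)cc(C(=O)O[C@@H]2CO[C@H]3[C@@H]2OC[C@@H]3OC(=O)c2ccccc2OC(C)=O)c1` differs from compound 1 as follows: 3,5-diethoxyphenyl in place of methyl on a carbonyl carbon. This change resembles the step of an at least 35-fold higher number from compound 1 to compound 2 (1.54 log units; beyond the scatter), where an aryl group likewise stood in place of methyl on a carbonyl carbon, so a large rise is expected here too. Compound 3 is therefore expected to show a step of about a 32-fold higher number from compound 1 to compound 3 (1.50 log units; beyond the scatter) in this assay. The estimate for compound 3 is 0.3 h, with a range from 0.05 h to 1.5 h. Because compound 2 sits at the limit of > 0.333 h in this assay, at which 1 of the 2 values shown sits, compound 3 may likewise return only a limit.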

Compound 3, half-life: 0.0283 h
For compound 3 the middle estimate is 11-fold (1.03 log units) above the measured one; the whole stated range lies above it.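

In this assay, an aryl group on this carbonyl carbon does not bring one fixed size of change: 3,5-diethoxyphenyl in place of methyl gives a 3.0-fold higher number from compound 1 to compound 3 (0.47 log units; beyond the scatter), a modest step. Exchanging 3,5-diethoxyphenyl for 4-phenylphenyl at the same place gives an at least 11-fold lower number from compound 2 to compound 3 (1.07 log units; beyond the scatter), a large step, so which aryl group stands here counts, not only the presence of one. This second step rests on a value that is not a plain number: the limit of > 0.333 h in this assay, at which 1 of the 3 values shown sits.

The compounds shown leave open how an unsubstituted phenyl, or a phenyl ring carrying an amine or a carboxylic acid, would stand on this carbonyl carbon in this assay. On these data alone, with compound 2 standing as a limit, the full size of its step to compound 3 also stays open.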